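Swapping a bicyclic tail for a carbamate chain

This account rests on a few compounds, and the source may have more. Where it says the series, first, only, none or still open, it means among the compounds named here.

Compound 1 `CCCSc1nc(Cl)c2c(n1)N(Cc1ccccc1)C(C(=O)O)N2` gives > 64000 nM in a functional assay on TE-1 cells (Homo sapiens) for antiproliferative activity, read by MTT assay, with a stated time of 72 h; a higher number here means a weaker inhibitor, a lower number a stronger inhibitor.
Compound 2 `CCCSc1nc(Cl)c2c(n1)N(Cc1cccs1)C(C(=O)N1CCN(C)CC1)N2` gives 39400 nM in this assay.
Compound 3 `CCCSc1nc(Cl)c2c(n1)N(Cc1ccccc1)C(C(=O)NCCC1=CCc3ccccc31)N2` gives 30000 nM in this assay.

The value of compound 1 is a limit of the assay, not a number. Of the two numbers, compound 3 has the lower one, while compound 2 sits within the usual scatter of it, so the two cannot be ordered. Compound 4 `CCCSc1nc(Cl)c2c(n1)N(Cc1ccccc1)C(C(=O)NCCNC(=O)OC(C)(C)C)N2` carries a group of 8 heavy atoms (5 carbon, 1 nitrogen, 2 oxygen; no ring) in place of a group of 9 heavy atoms (9 carbon; one five-membered non-aromatic ring of carbon only, one six-membered aromatic ring of carbon only), on a saturated chain carbon, two bonds along the chain from an amide-type nitrogen. No measured pair among these compounds bears on this kind of change, and all three numbers sit in a weak range. The step from compound 3 to compound 4 is expected to be small, a 1.3-fold higher number from compound 3 to compound 4 (0.12 log units; within the scatter), perhaps slightly toward weaker inhibition. Compound 4 is therefore estimated at 40000 nM, between 15000 nM and 100000 nM.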

Compound 4, half-maximal inhibitory concentration: > 64000 nM
Compound 4 was reported as a limit; the forecaster's own chance of this, stated with the estimate: 30%; at least 1.6-fold (0.20 log units) between middle value and limit.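

Putting (tert-butoxycarbonyl)amino in place of the group with two rings, on a saturated chain carbon, two bonds along the chain from an amide-type nitrogen, brings an at least 2.1-fold higher number from compound 3 to compound 4 (0.32 log units; beyond the scatter). Among these compounds, this is the first readable step at this position, and it points toward weaker inhibition in this assay. The step between the two compounds that sit at the limit cannot be read: the limit of > 64000 nM in this assay, at which 2 of the 4 values shown sit.

Open, on these data alone, is how a plain primary amine at this place, or a longer chain carrying the two-ring group, would read. One step cannot show which part of the exchanged group matters.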